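This account rests on a few compounds, and the source may have more. Where it says the series, first, only, none or still open, it means among the compounds named here.

Measured so far:
- compound 1, `Cc1c(CCCC(=O)O)c2cccc(/C=C/c3ccc(OCCCCc4c(F)c(F)cc(F)c4F)cc3)c2n1CC(=O)O`: 2.2 nM
- compound 2, `Cc1c(Cl)cccc1CCCCOc1ccc(C#Cc2cccc3c(CCCC(=O)O)c(C)n(CCCCC(=O)O)c23)cc1`: 56 nM

Both numbers come from a functional assay on CHO-K1 cells for antagonist activity at cysteinyl leukotriene receptor 1 (Homo sapiens), read by fluorescence and calcium flux, with stated times of 30 min and 1 h; on this read-out higher numbers stand for weaker inhibition and lower numbers for stronger inhibition. Of the two, compound 1 gives the lower number; compound 2 gives a higher number, and that gap lies beyond the scatter. The two compounds differ at several places, so the gap is not tied to any single change.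

Compound 3, `Cc1c(CCCC(=O)O)c2cccc(/C=C/c3ccc(OCCCCc4cc(F)c(F)c(F)c4F)cc3)c2n1CC(=O)O`, is not yet measured. It differs from compound 1 in one place only: 2,3,4,5-tetrafluorophenyl in place of 2,3,5,6-tetrafluorophenyl on a saturated chain carbon, four bonds along the chain from an oxygen on an aromatic ring. The same atoms are present in both; only the placing of the fluorines on the ring changes.

Among the compounds with values here, with no pair of measured compounds showing a step of this kind, the expectation rests on compound 1 alone. A shift of the fluorine pattern on a terminal ring is expected to change the number little, so the step from compound 1 to compound 3 is expected to be a 1.4-fold higher number from compound 1 to compound 3 (0.13 log units; within the scatter), not beyond the scatter. In this assay compound 3 is estimated at 3 nM, within 1 nM to 10 nM.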

Compound 3, half-maximal inhibitory concentration: 0.8 nM
For compound 3 the middle estimate is 3.8-fold (0.57 log units) above the measured one; measured number below the stated range.
By their numbers in this assay, from the lowest: compound 3; then compound 1; then compound 2.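

In this assay, 2,3,4,5-tetrafluorophenyl in place of 2,3,5,6-tetrafluorophenyl on the saturated chain gives a 2.8-fold lower number from compound 1 to compound 3 (0.44 log units; beyond the scatter), a modest step. The two groups have the same atoms and the same counts of hydrogen-bond donors and acceptors, so this position responds to the arrangement of the fluorines alone, not only to larger differences such as those separating compound 1 from compound 2. No measurement shown here accounts for the direction of this step.

Going by these compounds, how a plain phenyl or a pentafluorophenyl at this place would compare with compound 3 remains open, and with it whether the fluorines are needed at all. Also open, on these data alone, is whether the same change of fluorine pattern would give a similar step on the core of compound 2.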